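Cyanosulfanyl added to a fused core tested against leukemia cells

The source may report more compounds than this note shows. Statements on the series, on what has been measured and on what is new or still open speak of the compounds shown alone.

Compound 1, with the structure `Clc1ccc(Cc2nn3cc(-c4ccc(Br)cc4)nc3s2)cc1`, was tested in an ADME assay on CCRF-CEM cells (Homo sapiens) for cytotoxicity, with a stated time of 72 h; a lower number here means a stronger inhibitor, a higher number a weaker inhibitor. In this assay compound 1 reaches only the assay limit of > 250000 nM, so no number is known for it. Two close relatives exist. Compound 2, `Clc1ccc(Cc2nn3cc(-c4ccccc4)nc3s2)cc1`, gives in this assay only the limit of > 250000 nM. Compound 3, `O=[N+]([O-])c1ccc(-c2cn3nc(Cc4ccc(Cl)cc4)sc3n2)cc1`, gives in this assay only the limit of > 250000 nM. The steps among them, a step that the two limits leave unreadable from compound 1 to compound 2, a step that the two limits leave unreadable from compound 1 to compound 3 and a step that the two limits leave unreadable from compound 2 to compound 3, cannot be sized, because all three compounds sit at the limit of > 250000 nM in this assay, at which 3 of the 3 values shown sit. Compound 4, `N#CSc1c(-c2ccc(Br)cc2)nc2sc(Cc3ccc(Cl)cc3)nn12`, is not yet measured. It differs from compound 1 by cyanosulfanyl in place of hydrogen on an aromatic carbon. Among the compounds with values here, no measured step speaks to this change, and the three measured compounds give no readable number to build on. Compound 4 is therefore expected to remain weak in this assay, with an estimate of 250000 nM spanning 40000 nM to 1000000 nM. The expected step of a number no higher from compound 1 to compound 4 (the limit leaves the size open) is thus close to none beyond the scatter.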

Compound 4, half-maximal inhibitory concentration: 61000 nM
Compound 4: middle estimate off by 4.1-fold (0.61 log units), on the high side; low and high end bracket the measured number.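

Placing cyanosulfanyl in place of hydrogen on this aromatic carbon of the shared core gives, in this assay, an at least 4.0-fold lower number from compound 1 to compound 4 (0.61 log units; beyond the scatter). Compound 4 is the only one of the four compounds with a measured number, so this position is the one place shown where a change has a readable result. The true size of the step stays open and this figure is only a minimum, because compound 1 has no number of its own: the limit of > 250000 nM in this assay, at which 3 of the 4 values shown sit.

As far as these compounds go, the steps among compound 1, compound 2 and compound 3 cannot be read, and it remains open whether cyanosulfanyl would have the same result without the bromo group or with nitro in its place. From the compounds shown here alone, it is also open whether the sulfur matters, or whether a simple nitrile, a methylthio group or an amine on the same carbon would give a similar number.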